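Ring-nitrogen aryl swap within a shared core

The source may hold more compounds than are shown below. What is called first, only, known or untested is meant among the compounds shown, and "the series" means these compounds.

compound 1 `Nc1scc(CN2CCN(c3cccc(C(F)(F)F)c3)CC2)c1C(=O)c1ccc(Cl)cc1` gives -80%
compound 2 `Nc1scc(CN2CCC(c3ccc(Cl)cc3)CC2)c1C(=O)c1ccc(Cl)cc1` gives -61%
compound 3 `Nc1scc(CN2CCN(c3cccc(F)c3)CC2)c1C(=O)c1cccc(C(F)(F)F)c1` gives -62%

In a functional assay on CHO cells with adenosine receptor A1 (Homo sapiens) as the target, read by cAMP accumulation and immunoassay, with a stated time of 6 min, tested at 10 uM (a lower number here means a stronger effect, a higher number a weaker effect of the compound at the concentration tested), compound 1 stands lowest of the three measured numbers; compound 3 lies nearest, higher by a margin beyond the usual scatter, and compound 2 furthest, also beyond it. Compound 4 `Nc1scc(CN2CCN(c3ccccc3F)CC2)c1C(=O)c1ccc(Cl)cc1` is not yet measured. It differs from compound 1 in one place: 2-fluorophenyl in place of 3-(trifluoromethyl)phenyl on an amine nitrogen in a ring. For the measured compounds named here, no two measured compounds differ in only one place, so the effect of a change at this ring nitrogen alone has not been isolated in this set. The other two measured compounds, with compound 3 giving -62%, sit well above compound 1. The step from compound 1 to compound 4 is expected to be a number 20 percentage points higher from compound 1 to compound 4 (beyond the scatter), toward a weaker effect and beyond the scatter. Compound 4 is estimated at -60%, within a range from -78% to -38%.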

Compound 4, a percentage reported as activity, at one concentration (the size of the read-out at that concentration, not a potency): -15%
Compound 4: the middle estimate sits 45 percentage points below what was measured; the measured number lies above the stated range.
By their numbers in this assay, from the lowest: compound 1; then compounds 3 and 2 (each within the scatter of the next); then compound 4.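

Placing 2-fluorophenyl in place of 3-(trifluoromethyl)phenyl on an amine nitrogen in a ring gives, in this assay, a number 65 percentage points higher from compound 1 to compound 4 (beyond the scatter), toward a weaker effect. For the compounds shown here, as the first single-place step, it shows that the aryl group at this ring nitrogen can alone change the read-out substantially with the rest of compound 1 held constant. Nothing measured here accounts for the step.

The compounds shown leave open whether the substituent or its place on the phenyl ring drives this step. A 2-(trifluoromethyl)phenyl group on the core of compound 1 would separate the two.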